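The source may hold more compounds than are shown below. What is called first, only, known or untested is meant among the compounds shown, and "the series" means these compounds.

Measured in an ADME assay on Raji cells (Homo sapiens) for cytotoxicity, with a stated time of 72 h; on this read-out lower numbers stand for an effect already at smaller amounts and higher numbers for an effect only at larger amounts of compound
- Compound 1 `Cc1ccc(NC(=O)Nc2cc(C)nc3ccccc23)cc1` gives > 25000 nM as a limit
- Compound 2 `Cc1cc(NC(=O)Nc2ccc(N(C)C)cc2)c2ccccc2n1` gives > 25000 nM as a limit

Compound 2 stands only on this limit, with no number to work from. Compound 3 `COC(=O)c1ccc(NC(=O)Nc2cc(C)nc3ccccc23)cc1` carries methoxycarbonyl in place of dimethylamino on an aromatic carbon, para to a large group (methoxycarbonyl in place of dimethylamino on an aromatic carbon). Among the compounds with values here, the one measured step that bears on this change is a step that the two limits leave unreadable from compound 1 to compound 2 and its size cannot be read. The evidence so far is the limit of > 25000 nM in this assay, at which 2 of the 2 values shown sit, and it gives no direction. No step beyond the scatter is therefore expected in this assay, and the estimate is a number no higher from compound 2 to compound 3 (the limit leaves the size open) in no firm direction. Compound 3 is estimated at 25000 nM with an expected range from 8000 nM to 50000 nM and a limit reading is the likeliest outcome.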

Compound 3, half-maximal effective concentration: 17000 nM
Compound 3: the middle estimate sits 1.5-fold (0.17 log units) above what was measured; the range from low to high includes it.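

Within the data shown here, compound 3 is the first compound here to give a number rather than a limit in this assay, so methoxycarbonyl on this aromatic carbon, para to a large group, gives a readable value. With dimethylamino replaced, the result is an at least 1.4-fold lower number from compound 2 to compound 3 (0.16 log units; that floor lies within the scatter), and with methyl replaced, it is an at least 1.4-fold lower number from compound 1 to compound 3 (0.16 log units; that floor lies within the scatter), so neither floor establishes a real change. Limits still make up most of the read-out: the limit of > 25000 nM in this assay, at which 2 of the 3 values shown sit.

From the compounds shown here alone, it remains open whether a carboxylic acid or a primary amide on this carbon would also give a number. The size of the true gap to compound 1 and compound 2 also stays unresolved.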